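A trifluoromethylphenyl in place of a difluorophenyl

A few compounds are considered here, and "the series" means these few. Any claim that something is new, unique, unknown or untested is made for them only; others in the source may bear on it.

Within the data shown here, in a functional assay on A549 cells (Homo sapiens) for inhibition, read by MTT assay, with a stated time of 72 h (a lower number here means a stronger inhibitor, a higher number a weaker inhibitor), compound 3 `CN(C(=O)NC(=O)c1ccc(F)c(F)c1)c1nc(C(F)(F)F)c(C(=O)N/N=C/c2cc(C(F)(F)F)cc(C(F)(F)F)c2)s1` gives 5.47 ug/mL, one of only two numbers in this set, and compound 2 `CN(C(=O)NC(=O)c1ccccc1F)c1nc(C(F)(F)F)c(C(=O)N/N=C/c2cc(C(F)(F)F)cc(C(F)(F)F)c2)s1` gives 5.43 ug/mL, within the scatter of it. Compound 1 `CNc1nc(C)c(C(=O)N/N=C/c2ccccc2C(F)(F)F)s1` is reported only as a limit, > 100 ug/mL. Among the measured compounds shown here, the one measured step that bears on the next change is a 1.0-fold higher number from compound 2 to compound 3 (0.00 log units; within the scatter), where swapping one fluorophenyl for another on the carbonyl carbon left the number unchanged. Compound 4 `CN(C(=O)NC(=O)c1cccc(C(F)(F)F)c1)c1nc(C(F)(F)F)c(C(=O)N/N=C/c2cc(C(F)(F)F)cc(C(F)(F)F)c2)s1` differs from compound 3 by 3-(trifluoromethyl)phenyl in place of 3,4-difluorophenyl on a carbonyl carbon. Since that earlier step at the same place moved nothing beyond the scatter, no shift beyond the scatter is expected here either. The expected step is a 1.0-fold higher number from compound 3 to compound 4 (0.00 log units; within the scatter). Compound 4 is estimated at 5.5 ug/mL, with a range from 2.5 ug/mL to 12 ug/mL.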

Compound 4, half-maximal inhibitory concentration: 8.2 ug/mL
Beside the measured number, compound 4's estimate is 1.5-fold (0.17 log units) below it; the range from low to high includes it.
By their numbers in this assay, from the lowest: compounds 2, 3 and 4 (each within the scatter of the next). At a limit, above all of these: compound 1.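

In this assay, 3-(trifluoromethyl)phenyl on the carbonyl carbon, a group of 10 heavy atoms in place of the 8 of 3,4-difluorophenyl, gives a 1.5-fold higher number from compound 3 to compound 4 (0.18 log units; within the scatter) and, measured against 2-fluorophenyl, a 1.5-fold higher number from compound 2 to compound 4 (0.18 log units; within the scatter) with no shift beyond the scatter in either step. The position therefore accepts a phenyl carrying trifluoromethyl as well as one carrying only fluorine, which the fluorophenyl pair alone could not show. The compounds shown leave open whether an amine or a carboxylic acid on this phenyl would keep the number in this range. No measurement shown here accounts for this result.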